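Series notes: cyano to trifluoromethyl at the position of compound 2

The compounds below may be only part of what the source reports. "The series", "measured", "known", "first", "only" and "open" are said of these compounds alone.

Measured compounds:
compound 1, `Cc1cc(-n2ccnc2)c(S(C)(=O)=O)cc1C(=O)N=C(N)N`: 23 nM
compound 2, `Cc1cc(C#N)c(S(C)(=O)=O)cc1C(=O)N=C(N)N`: 70 nM

Among the compounds with values here, in a functional assay for inhibition of sodium/hydrogen exchanger (Oryctolagus cuniculus) (a higher number here means a weaker inhibitor, a lower number a stronger inhibitor), compound 2 gives 70 nM, the highest of the two numbers so far. Within the data shown here, its nearest neighbour is compound 1, which gives 23 nM; the only measured step, a 3.0-fold higher number from compound 1 to compound 2 (0.48 log units; beyond the scatter), is modest and lies beyond the scatter.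

Compound 3, `Cc1cc(C(F)(F)F)c(S(C)(=O)=O)cc1C(=O)N=C(N)N`, differs from compound 2 by trifluoromethyl in place of cyano on an aromatic carbon. Among the measured compounds shown here, no measured step exchanges cyano for trifluoromethyl. For the measured compounds named here, the single step available, a 3.0-fold higher number from compound 1 to compound 2 (0.48 log units; beyond the scatter), concerns the same position but a different pair of groups, so it bears on the new change only loosely: it shows that the group at this position can shift the number by a modest amount, without indicating the direction for trifluoromethyl. The expectation is therefore a small step, if any, a 1.4-fold higher number from compound 2 to compound 3 (0.15 log units; within the scatter), not clearly beyond the scatter. Compound 3 is estimated at 100 nM, with a range from 35 nM to 300 nM.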

Compound 3, half-maximal inhibitory concentration: 37 nM
Estimate against measurement, compound 3: 2.7-fold (0.43 log units) above; the measured number falls inside the stated range.
By their numbers in this assay, from the lowest: compounds 1, 3 and 2 (each within the scatter of the next, the first and the last beyond it).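

In this assay, the trifluoromethyl group cannot be separated from either earlier group, with a 1.9-fold lower number from compound 2 to compound 3 (0.28 log units; within the scatter) and a 1.6-fold higher number from compound 1 to compound 3 (0.21 log units; within the scatter), even though the other step at this position, a 3.0-fold higher number from compound 1 to compound 2 (0.48 log units; beyond the scatter), lies beyond the scatter. A ring at this position is therefore not required for a number within the scatter of compound 1, as compound 3 shows, although compound 2, also without a ring, goes against any general rule that ring-free groups behave alike here. No measurement at hand accounts for these numbers.

On these data alone, whether an amine, a carboxylic acid or a longer alkyl chain at this position would stay within the scatter of compound 1 remains open. Also open, as far as these compounds go, is whether the trifluoromethyl for cyano exchange would give a similar step on a core with another group in place of the methylsulfonyl group.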